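Amide variation on the hydroxy acid series

The compounds below may be only part of what the source reports. "The series", "measured", "known", "first", "only" and "open" are said of these compounds alone.

Of the compounds shown here, two have been measured in an assay on microsomes from liver for inhibition of 3-hydroxy-3-methylglutaryl-coenzyme A reductase (Rattus norvegicus); on this read-out higher numbers stand for weaker inhibition and lower numbers for stronger inhibition. Compound 1 `CC(C)c1c(C(=O)N(C)Cc2cccc(F)c2)nn(-c2ccc(F)cc2)c1CC[C@@H](O)C[C@@H](O)CC(=O)O` gives 4.1 nM and compound 2 `CC(C)c1c(C(=O)N2CCCCC2)nn(-c2ccc(F)cc2)c1OC[C@@H](O)C[C@@H](O)CC(=O)O` gives 47 nM. Compound 2 thus stands at the highest number of the two, with compound 1 the nearer and only comparison, and that gap is beyond the usual scatter. For the measured compounds named here, compound 1 and compound 2 differ in more than one place, so the two values show only that the pair sits apart.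

Compound 3 `CC(C)c1c(C(=O)N(C)[C@H](C)c2ccccc2)nn(-c2ccc(F)cc2)c1OC[C@@H](O)C[C@@H](O)CC(=O)O` has not yet been measured. It differs from compound 2 by methyl(1-phenylethyl)amino in place of piperidin-1-yl on a carbonyl carbon. Compound 1, which carries a methyl-substituted amide nitrogen with an aromatic ring beside it, gives 4.1 nM, and on that limited ground the step from compound 2 to compound 3 is expected to be a 3.1-fold lower number from compound 2 to compound 3 (0.50 log units; beyond the scatter), toward stronger inhibition. For compound 3 a value of about 15 nM is estimated, within 5 nM to 50 nM.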

Compound 3, half-maximal inhibitory concentration: 21 nM
Compound 3: middle estimate off by 1.4-fold (0.15 log units), on the low side; low and high end bracket the measured number.
By their numbers in this assay, from the lowest: compound 1; then compound 3; then compound 2.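

On a carbonyl carbon, methyl(1-phenylethyl)amino in place of piperidin-1-yl gives a 2.2-fold lower number from compound 2 to compound 3 (0.35 log units; beyond the scatter) in this assay, a modest change toward stronger inhibition. For the compounds shown here, this is the first comparison that differs in one place, and it shows that inhibition at this position does not depend on keeping the six-membered non-aromatic ring: an open amino group carrying a six-membered aromatic ring of carbon only and one defined stereocentre also gives a measurable step. Nothing available bears on the reason for this step.

Still open, going by these compounds, is how the step would read with the mirror-image 1-phenylethyl group, or with a benzylamino group carrying the amide hydrogen. Also open, on these data alone, is where a morpholin-4-yl group on the same carbonyl carbon would fall relative to piperidin-1-yl.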